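Series notes: compound 4 from compound 3

The source may hold more compounds than are shown below. What is called first, only, known or untested is meant among the compounds shown, and "the series" means these compounds.

Of the compounds shown here, three have numbers so far. Among the compounds with values here, compound 1 `COC(=O)/C=C/c1cccc(N(Cc2ccc(/C=C/c3c(Cl)cccc3Cl)cc2)C(=O)C(C)C)c1` gives 195 nM in an assay on isolated protein with Bile acid receptor (Homo sapiens) as the target; on this read-out lower numbers stand for an effect already at smaller amounts and higher numbers for an effect only at larger amounts of compound; compound 2 `COC(=O)/C=C/c1cccc(N(Cc2ccc(-c3ccc(OC(F)(F)F)cc3)cc2)C(=O)C(C)C)c1` gives 219 nM; the single one-place step on record, a 1.1-fold higher number from compound 1 to compound 2 (0.05 log units; within the scatter), changed nothing beyond the scatter. Compound 3 `COC(=O)/C=C/c1cccc(N(Cc2ccc(-c3ccc(C(C)(C)C)cc3)cc2)C(=O)C2CCCCC2)c1` gives 132 nM and stands at the lowest of the three numbers, though its gaps to compound 1 and to compound 2 both lie within the scatter, so the three cannot be ordered.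

Compound 4 `COC/C=C/c1ccc(CN(C(=O)C2CCCCC2)c2cccc(/C=C/C(=O)OC)c2)cc1` is not yet measured. Its change from compound 3 is 3-methoxyprop-1-en-1-yl in place of 4-(tert-butyl)phenyl on an aromatic carbon, on an aromatic carbon, para to a large group. Within the data shown here, the only measured step sits at the same place on the ring and swapped one large group for another without effect beyond the scatter. Among the measured compounds shown here, no measured step swaps a six-membered aromatic ring for a short chain of 5 heavy atoms carrying one hydrogen-bond acceptor, so the present change is outside what the series has tested. A modest weakening, a 2.4-fold higher number from compound 3 to compound 4 (0.38 log units; beyond the scatter), is expected, with the range kept wide for lack of a matching precedent. Compound 4 is therefore estimated at 320 nM, between 110 nM and 950 nM.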

Compound 4, half-maximal effective concentration: 233 nM
The estimate for compound 4 lay 1.4-fold (0.14 log units) above the measured number; low and high end bracket the measured number.
By their numbers in this assay, from the lowest: compounds 3, 1, 2 and 4 (each within the scatter of the next).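

In this assay, 3-methoxyprop-1-en-1-yl in place of 4-(tert-butyl)phenyl gives a 1.8-fold higher number from compound 3 to compound 4 (0.25 log units; within the scatter) and so stays within the scatter, which shows that on this aromatic carbon, para to a large group, the six-membered aromatic ring of carbon only is not needed to hold the number in this range. The earlier step, a 1.1-fold higher number from compound 1 to compound 2 (0.05 log units; within the scatter), exchanged one large group for another, whereas here 10 heavy atoms leave and 5 enter, with no ring and with 1 hydrogen-bond acceptor in place of 0, so this position now accepts a much wider range of groups than the first step could show. No supporting data bear on the reason for this result at this position.

The compounds shown do not separate the loss of the ring from the entry of the methoxy oxygen, a question that a plain propenyl chain, a longer ether chain, or a chain ending in an amine or a carboxylic acid would address. Also open, on these data alone, is whether a short chain at this position gives a similar number when the cyclohexyl amide of compound 4 is exchanged for the amide carried by compound 1.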